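Butyl on the phenyl ring: compound 3 to compound 4

A few compounds are considered here, and "the series" means these few. Any claim that something is new, unique, unknown or untested is made for them only; others in the source may bear on it.

Measured so far:
compound 1, `CCCCc1ccc(-c2cc(Cl)cc(C(=O)Nc3nn[nH]n3)n2)cc1`, 83%
compound 2, `CCCCc1ccc(-c2cc(C)cc(C(=O)Nc3nn[nH]n3)n2)cc1`, 67%
compound 3, `CCc1cc(C(=O)Nc2nn[nH]n2)nc(-c2ccccc2)c1`, 53%

In a functional assay on the whole organism with Rattus norvegicus as the target, at a dose of 3 mg/kg by the oral route (a higher number here means a stronger effect of the compound at the dose given, a lower number a weaker effect), compound 3 stands lowest of the three measured numbers; compound 2 is nearest to it, and compound 1 is furthest. Going by the values given here, the only measured step between two compounds that differ in one place is a number 16 percentage points lower from compound 1 to compound 2 (beyond the scatter), and it concerns a group on the other ring of the shared core, so it does not bear directly on the change at hand. Compound 4, `CCCCc1ccc(-c2cc(CC)cc(C(=O)Nc3nn[nH]n3)n2)cc1`, differs from compound 3 by butyl in place of hydrogen on an aromatic carbon. Among the compounds with values here, no single-place step for this change is available; what the data show is that compound 1 and compound 2, which both carry the butyl group, give higher numbers than compound 3, which does not, though each also differs from compound 3 at the second position. On this basis a rise is expected, of the size a number 15 percentage points higher from compound 3 to compound 4 (beyond the scatter), with wide uncertainty. Compound 4 is therefore estimated at 68% in this assay, within a range from 50% to 85%.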

Compound 4, a percentage reported as inhibition, in the whole organism at one dose (the size of the read-out at that dose, not a potency): 70%
For compound 4 the middle estimate is 2 percentage points below the measured one, within the range that was stated.
By their numbers in this assay, from the lowest: compound 3; then compounds 2 and 4 (each within the scatter of the next); then compound 1.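

In this assay, the butyl group on an aromatic carbon, para to a large group, now has a single-place step of its own: a number 17 percentage points higher from compound 3 to compound 4 (beyond the scatter). Where the compounds carrying butyl differ from one another, methyl in place of hydrogen on the saturated chain carbon makes no difference that can be told from the scatter, with a number 3 percentage points higher from compound 2 to compound 4 (within the scatter), whereas replacing chloro with ethyl does, with a number 13 percentage points lower from compound 1 to compound 4 (beyond the scatter). Nothing available here explains either of the steps beyond the scatter.

The compounds shown leave open whether a shorter chain such as propyl or a longer one such as hexyl would give a different number from butyl at that aromatic carbon. They also leave open how a methoxy group or an amine would compare with chloro and ethyl on the shared core.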